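Methoxy for chloro in a series without spread

The compounds below may be only part of what the source reports. "The series", "measured", "known", "first", "only" and "open" are said of these compounds alone.

In an ADME assay on L6 cells (Rattus norvegicus) for cytotoxicity, read by resazurin assay, with a stated time of 70 h (a lower number here means a stronger inhibitor, a higher number a weaker inhibitor), three compounds sharing one core have been measured. Compound 1 `CC(=O)Oc1ccc2c(c1)C(C)=CC(C)(C)N2Cc1ccc(C#N)cc1` gives 29000 nM, compound 2 `CC(=O)Oc1ccc2c(c1)C(C)=CC(C)(C)N2Cc1cccc(C#N)c1` gives 31000 nM, and compound 3 `CC(=O)Oc1ccc2c(c1)C(C)=CC(C)(C)N2Cc1cccc(Cl)c1` gives 29000 nM. Compound 3 therefore stands level with compound 1 at the digits shown and within the scatter of compound 2.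

Compound 4 `COc1cccc(CN2c3ccc(OC(C)=O)cc3C(C)=CC2(C)C)c1` differs from compound 3 by one change: methoxy in place of chloro on an aromatic carbon. Methoxy takes the place of chloro on an aromatic carbon, meta to a large group, so that 3-chlorophenyl becomes 3-methoxyphenyl.

Within the data shown here, no measured step makes this exact exchange, and no measured compound carries methoxy. The closest evidence is the exchange of cyano for chloro, a 1.1-fold lower number from compound 2 to compound 3 (0.03 log units; within the scatter). The other two steps, a 1.1-fold higher number from compound 1 to compound 2 (0.03 log units; within the scatter) and no change at the digits printed from compound 1 to compound 3 (within the scatter), also stay within the scatter. With all three steps this small, no step beyond the scatter is expected in this assay, in either direction.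

The estimate amounts to a 1.0-fold higher number from compound 3 to compound 4 (0.01 log units; within the scatter), an expected step within the scatter. For compound 4 the expected value is 30000 nM, with an estimated range from 18000 nM to 48000 nM.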

Compound 4, half-maximal inhibitory concentration: 29000 nM
Compound 4: middle estimate off by 1.0-fold (0.01 log units), on the high side, within the range that was stated.
By their numbers in this assay, from the lowest: compounds 1, 3, 4 and 2 (each within the scatter of the next).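

In this assay, the first methoxy seen at this aromatic carbon gives no change at the digits printed from compound 3 to compound 4 (within the scatter) when it replaces chloro, so an exchange that brings in a group counted as a hydrogen-bond acceptor, and one more heavy atom, leaves the number where it stood. The comparison with the two nitrile compounds reads the same way, with a 1.1-fold lower number from compound 2 to compound 4 (0.03 log units; within the scatter) for methoxy in place of cyano on the same carbon and no change at the digits printed from compound 1 to compound 4 (within the scatter) for the wider exchange of 4-cyanophenyl for 3-methoxyphenyl, so chloro, cyano and methoxy at this place cannot be told apart in this assay, and none of the four compounds goes against that reading. Nothing shown here offers an explanation for why these exchanges leave the number in place.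

The compounds shown leave open whether an amine, a carboxylic acid or a longer chain such as butoxy on this aromatic carbon would bring a step beyond the scatter. Among these compounds, they also leave open whether the number would stay this level if the exchange were made on a core other than the one these four compounds share.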